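The compounds below may be only part of what the source reports. "The series", "measured", "known", "first", "only" and "open" are said of these compounds alone.

Compound 1 `COC(=O)c1cc(-c2cccc(NC(=O)c3ccc(/C=C/C(=O)c4ccc(OC)cc4)cc3)c2)on1`, measured in an ADME assay on Vero cells (Chlorocebus sabaeus) for cytotoxicity, read by MTT assay, with a stated time of 72 h (a lower number here means that less compound is tolerated, a higher number that more compound is tolerated), gives a limit of > 10 ug/mL.
Compound 2 `COC(=O)c1cc(-c2cccc(NC(=O)c3ccc(/C=C/C(=O)c4ccc(Br)cc4)cc3)c2)on1` gives a limit of > 20 ug/mL.
Compound 3 `COC(=O)c1cc(-c2cccc(NC(=O)c3ccc(/C=C/C(=O)c4cccc(Br)c4)cc3)c2)on1` gives a limit of > 100 ug/mL.

All three results are limits of the assay rather than numbers, so compound 3 stands only at a limit, and the two other values shown are limits as well. The steps a step that the two limits leave unreadable from compound 1 to compound 2, a step that the two limits leave unreadable from compound 1 to compound 3 and a step that the two limits leave unreadable from compound 2 to compound 3 are therefore unreadable in size. Compound 4 `COC(=O)c1cc(-c2cccc(NC(=O)c3ccc(/C=C/C(=O)c4ccc([N+](=O)[O-])cc4)cc3)c2)on1` differs from compound 3 by 4-nitrophenyl in place of 3-bromophenyl on a carbonyl carbon. Within the data shown here, since no measured step reads a size, no step beyond the scatter is expected in this assay in either direction. The step of a number no higher from compound 3 to compound 4 (the limit leaves the size open) is therefore expected to be small. Compound 4 is estimated at 100 ug/mL, between 30 ug/mL and 300 ug/mL, and is expected most likely to be reported as a limit again.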

Compound 4, half-maximal cytotoxic concentration: > 20 ug/mL
Compound 4: no number, only a limit; the forecaster's own chance of this, stated with the estimate: 70%; the middle value is on the limit's open side.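

Compound 4, like compound 1, compound 2 and compound 3, gives only a limit in this assay, so no step among these compounds can be read in size. The compounds shown leave open whether changing the aromatic group on the carbonyl carbon shifts the tolerated concentration at all.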